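From compound 2 to compound 4: a step among limits

A few compounds are considered here, and "the series" means these few. Any claim that something is new, unique, unknown or untested is made for them only; others in the source may bear on it.

Measured in an ADME assay on Vero cells (Chlorocebus sabaeus) for cytotoxicity (a lower number here means that less compound is tolerated, a higher number that more compound is tolerated), each value a limit and not a number:
Compound 1 `COc1ccc(-c2nc3c(NC4CCCC4)cccn3c2-c2ccnc(NC3CCCC3)n2)cc1` gives > 10000 nM as a limit.
Compound 2 `Oc1ccc(-c2nc3c(NC4CCCC4)cccn3c2-c2ccnc(NC3CCCC3)n2)cc1` gives > 40000 nM as a limit.
Compound 3 `COc1cccc(-c2nc3c(Cl)cccn3c2-c2ccnc(NC3CCCC3)n2)c1` gives > 40000 nM as a limit.

Compound 2 has no number to step from, only a limit (the limit of > 40000 nM in this assay, at which 2 of the 3 values shown sit). Compound 4 `COc1cccc(-c2nc3c(NC4CCCC4)cccn3c2-c2ccnc(NC3CCCC3)n2)c1` has 3-methoxyphenyl in place of 4-hydroxyphenyl on an aromatic carbon. Within the data shown here, the one measured step that bears on this change (a step that the two limits leave unreadable from compound 1 to compound 2) has no readable size. Compound 1 also rests on a limit (the limit of > 10000 nM in this assay, at which 1 of the 3 values shown sits). No step beyond the scatter is therefore expected in this assay, in either direction. The expected change is an at least 1.3-fold lower number from compound 2 to compound 4 (0.12 log units; that floor lies within the scatter), an estimate only. Compound 4 is expected at 30000 nM, with an estimated range from 10000 nM to 60000 nM and a report as a limit likely.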

Compound 4, half-maximal cytotoxic concentration: > 40000 nM
Compound 4: no number, only a limit; the forecaster's own chance of this, stated with the estimate: 85%; middle value at least 1.3-fold (0.12 log units) away from the limit.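

In this assay, among these compounds, compound 4 gives > 40000 nM, a limit and not a number, so no step from compound 1, compound 2 or compound 3 can be read. The compounds shown leave open where any of these four would give an actual number in this assay.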